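The compounds below may be only part of what the source reports. "The series", "measured", "known", "first", "only" and "open" are said of these compounds alone.

Compound 1 `COc1cc2ncnc(Nc3ccc(F)c(Cl)c3)c2cc1OCCCCC(=O)Nc1ccc(S(N)(=O)=O)cc1`: 35600 nM
Compound 2 `COc1cc2ncnc(Nc3ccc(Cl)c(C(F)(F)F)c3)c2cc1OCCCCC(=O)Nc1ccc(S(N)(=O)=O)cc1`: 3220 nM
Compound 3 `COc1cc2ncnc(Nc3cccc(Cl)c3F)c2cc1OCCCCC(=O)Nc1ccc(S(N)(=O)=O)cc1`: 6930 nM

In a functional assay on NCI-H1975 cells (Homo sapiens) for antiproliferative activity, read by MTT assay, with a stated time of 72 h (a higher number here means a weaker inhibitor, a lower number a stronger inhibitor), compound 1 stands with the highest number of the three measured compounds; its nearest neighbour is compound 3, and compound 2 lies furthest from it. The two measured steps that move away from compound 1 both change the aryl group on the nitrogen on the aromatic ring of the shared core, and both lower the number: an 11-fold lower number from compound 1 to compound 2 (1.04 log units; beyond the scatter) and a 5.1-fold lower number from compound 1 to compound 3 (0.71 log units; beyond the scatter). Compound 4 `COc1cc2ncnc(Nc3cc(F)c(F)c(F)c3)c2cc1OCCCCC(=O)Nc1ccc(S(N)(=O)=O)cc1` takes the same route, with 3,4,5-trifluorophenyl in place of 3-chloro-4-fluorophenyl on a nitrogen on an aromatic ring. Neither measured step uses this particular aryl group, so they bear on compound 4 only by showing that changes at this site have so far pulled the number down from compound 1, by a modest to large amount. A step of similar direction, though more uncertain in size, is therefore expected in this assay, a 2.5-fold lower number from compound 1 to compound 4 (0.41 log units; beyond the scatter). Compound 4 is estimated at 14000 nM, with a range from 4000 nM to 45000 nM.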

Compound 4, half-maximal inhibitory concentration: 20000 nM
Estimate against measurement, compound 4: 1.4-fold (0.15 log units) below; the range from low to high includes it.
By their numbers in this assay, from the lowest: compound 2; then compound 3; then compounds 4 and 1 (each within the scatter of the next).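

In this assay the step of a 1.8-fold lower number from compound 1 to compound 4 (0.25 log units; within the scatter) does not clear the scatter, so 3,4,5-trifluorophenyl cannot be told apart from 3-chloro-4-fluorophenyl here, whereas both earlier replacements could. Changing the aryl group on this nitrogen therefore does not lower the number in every case, and the choice of group matters, as the steps of a 2.9-fold higher number from compound 3 to compound 4 (0.46 log units; beyond the scatter) and a 6.2-fold higher number from compound 2 to compound 4 (0.79 log units; beyond the scatter) both lie beyond the scatter. The data shown offer no measurement that would account for these differences.

The compounds shown leave open how an aryl group bearing a nitrile, a methoxy group or an amine would behave at this position. They also leave open whether a shorter or longer chain would change the order seen among these aryl groups.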